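Cyano position on the benzyl ether series

The compounds below may be only part of what the source reports. "The series", "measured", "known", "first", "only" and "open" are said of these compounds alone.

- compound 1 `COc1cc(OC)c(-c2coc3cc(OCc4ccccc4)ccc3c2=O)cc1OC`: 1320 nM
- compound 2 `COc1cc(OC)c(-c2coc3cc(OCc4ccccc4C(F)(F)F)ccc3c2=O)cc1OC`: 6550 nM
- compound 3 `COc1cc(OC)c(-c2coc3cc(OCc4ccc(C#N)cc4)ccc3c2=O)cc1OC`: 4230 nM

Compound 3 has a number well above that of compound 1, and a 1.5-fold lower number from compound 2 to compound 3 (0.19 log units; within the scatter) places it within the scatter of compound 2. Compound 4 `COc1cc(OC)c(-c2coc3cc(OCc4ccccc4C#N)ccc3c2=O)cc1OC` has 2-cyanophenyl in place of 4-cyanophenyl on a saturated chain carbon bound to an oxygen on an aromatic ring. Among the measured compounds shown here, three steps bear on this. Substitution on the benzyl ring gave a 3.2-fold higher number from compound 1 to compound 3 (0.51 log units; beyond the scatter) and a 5.0-fold higher number from compound 1 to compound 2 (0.70 log units; beyond the scatter), and the group on compound 2 already occupies the 2-position named in 2-(trifluoromethyl)phenyl. The step between those two substituted compounds stayed within the scatter, so no step beyond the scatter is expected in a functional assay on HepG2 cells (Homo sapiens) for antiproliferative activity, read by MTT assay, with a stated time of 24 h; on this read-out higher numbers stand for weaker inhibition and lower numbers for stronger inhibition. The expected change is a 1.1-fold higher number from compound 3 to compound 4 (0.05 log units; within the scatter). Compound 4 is estimated at 4800 nM, with a range of 2200 nM to 10000 nM.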

Compound 4, half-maximal inhibitory concentration: > 10000 nM
Compound 4: no number, only a limit; the forecaster's own chance of this, stated with the estimate: 3%; at least 2.0-fold (0.31 log units) between middle value and limit.
By their numbers in this assay, from the lowest: compound 1; then compounds 3 and 2 (each within the scatter of the next). At a limit, above all of these: compound 4.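

In this assay compound 4 stands at a limit and not a number, so every step to it is a floor: the limit of > 10000 nM in this assay, at which 1 of the 4 values shown sits.

Going from 4-cyanophenyl to 2-cyanophenyl, with the same atoms joined differently, gives an at least 2.3-fold higher number from compound 3 to compound 4 (0.37 log units; beyond the scatter), so the place of the nitrile on the benzyl ring matters and not only its presence. The floor reaches an at least 7.5-fold higher number from compound 1 to compound 4 (0.87 log units; beyond the scatter), whereas an at least 1.5-fold higher number from compound 2 to compound 4 (0.18 log units; that floor lies within the scatter) does not set the trifluoromethyl and cyano groups apart.

Open, from the compounds shown here alone, is how an amine or a carboxylic acid would read in place of the nitrile on 2-cyanophenyl. Going by these compounds, the actual value of compound 4 also remains open.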